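Compound 1 and the loss of its chloronitrophenyl ketone

This account rests on a few compounds, and the source may have more. Where it says the series, first, only, none or still open, it means among the compounds named here.

Values in a functional assay on DU-145 cells (Homo sapiens) for inhibition, read by trypan blue exclusion, with a stated time of 96 h (a higher number here means a weaker inhibitor of growth, a lower number a stronger inhibitor of growth), are as follows
compound 1 `O=C(/C(=C\c1ccc([N+](=O)[O-])c(O)c1)SCc1ccc(Br)cc1)c1ccc([N+](=O)[O-])c(Cl)c1` gives 1000 nM
compound 2 `O=C(O)c1ccc(C(=O)/C(=C\c2ccc(Cl)c([N+](=O)[O-])c2)SCc2ccccc2F)cc1` gives 1000 nM
compound 3 `COc1cc(OC)c(/C=C(/SCc2ccc(Cl)c(Cl)c2)C(=O)c2ccc(Cl)cc2)c(OC)c1` gives 10000 nM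

Compound 1 stands level with compound 2 at the low end of these three numbers, while compound 3 lies beyond the scatter with a higher number. The step followed here leads to compound 4 `O=C(/C(=C\c1ccc([N+](=O)[O-])c(O)c1)SCc1ccc(Br)cc1)c1cc(Cl)ccc1O` in which 5-chloro-2-hydroxyphenyl takes the place of 3-chloro-4-nitrophenyl on a carbonyl carbon (5-chloro-2-hydroxyphenyl in place of 3-chloro-4-nitrophenyl on a carbonyl carbon). Going by the values given here, no pair of measured compounds differs in one place, so the data offer no direct precedent for this change. Compound 3 at 10000 nM also lacks the 3-chloro-4-nitrophenyl, although it differs from compound 1 elsewhere too, and this gives only weak support for expecting a higher number. The expected change is modest and towards weaker growth inhibition, estimated as a 2.5-fold higher number from compound 1 to compound 4 (0.40 log units; beyond the scatter) and possibly not beyond the scatter. The estimated value for compound 4 is 2500 nM with an expected range from 600 nM to 10000 nM in this assay as a rough guide.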

Compound 4, concentration for 50% growth inhibition: 10000 nM
Compound 4: the middle estimate sits 4.0-fold (0.60 log units) below what was measured, and the stated range covers the measured number.
By their numbers in this assay, from the lowest: compounds 1 and 2 (each within the scatter of the next); then compounds 3 and 4 (each within the scatter of the next).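

In this assay, 5-chloro-2-hydroxyphenyl in place of 3-chloro-4-nitrophenyl on a carbonyl carbon gives a 10-fold higher number from compound 1 to compound 4 (1.00 log units; beyond the scatter) and so moves the number beyond the scatter towards weaker growth inhibition. Going by these compounds alone, this is the one direct reading of this position, since no earlier pair differed in one place: with the rest of compound 1 held fixed, the ring on the carbonyl carbon alone shifts the number. No measurement shown accounts for this step.

The change swaps the whole ring, so the compounds shown do not separate the departure of the nitro group from the arrival of the hydroxyl group or the different placing of the chlorine. Also open, going by these compounds, is how an amine or a nitrile on that ring would read in this assay and whether any replacement at this position can hold the number of compound 1.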